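This account rests on a few compounds, and the source may have more. Where it says the series, first, only, none or still open, it means among the compounds named here.

The series keeps one core and varies the group on a double-bonded nitrogen, as in compound 1 `CC(C)C/N=c1\c(O)c(O)\c1=N/Cc1ccc(C#N)cc1`, compound 2 `C[C@@H](/N=c1\c(O)c(O)\c1=N/Cc1ccc(C#N)cc1)C(C)(C)C` and compound 3 `C/N=c1\c(O)c(O)\c1=N/Cc1ccc(C#N)cc1`. In a functional assay for inhibition, with Rattus norvegicus as the target (a higher number here means a weaker inhibitor, a lower number a stronger inhibitor), compound 3 gives > 30000 nM, which is a limit of the assay and not a number. In this assay compound 1 gives 10200 nM and compound 2 gives 270 nM. Compound 3 therefore stands at the weak end of the three.

The next structure is compound 4 `CCC(CC)/N=c1\c(O)c(O)\c1=N/Cc1ccc(C#N)cc1`, which has pentan-3-yl in place of methyl on a double-bonded nitrogen. Two measured steps leave the methyl group's place in the series from the other side: an at least 2.9-fold higher number from compound 1 to compound 3 (0.46 log units; beyond the scatter) and an at least 110-fold higher number from compound 2 to compound 3 (2.04 log units; beyond the scatter). The step of a 38-fold lower number from compound 1 to compound 2 (1.58 log units; beyond the scatter) shows that the number also depends strongly on which larger group is present, so the size of the gain is uncertain. Among these three compounds, the larger group goes with the lower number, and none goes against this.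

A large step to a lower number is therefore expected in this assay, estimated as an at least 20-fold lower number from compound 3 to compound 4 (1.30 log units; beyond the scatter). The estimated value for compound 4 is 1500 nM, with an expected range of 300 nM to 8000 nM.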

Compound 4, half-maximal inhibitory concentration: 1300 nM
For compound 4 the middle estimate is 1.2-fold (0.06 log units) above the measured one; the measured number falls inside the stated range.
By their numbers in this assay, from the lowest: compound 2; then compound 4; then compound 1. At a limit, above all of these: compound 3.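

In this assay, pentan-3-yl falls among the larger groups on the double-bonded nitrogen, giving a 7.8-fold lower number from compound 1 to compound 4 (0.89 log units; beyond the scatter) and a 4.8-fold higher number from compound 2 to compound 4 (0.68 log units; beyond the scatter), so the number drops in steps beyond the scatter from isobutyl through pentan-3-yl to 1,2,2-trimethylpropyl, and none of these three compounds goes against that order. Against methyl, the same position gives an at least 23-fold lower number from compound 3 to compound 4 (1.36 log units; beyond the scatter), which places the new group far from the small end of the series as well. The value of compound 3 is a limit and not a number, so this last step has a bound rather than a measured size: the limit of > 30000 nM in this assay, at which 1 of the 4 values shown sits.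

The compounds shown do not separate the total size of the group from its shape, since a straight pentyl chain or a cyclohexyl ring would be needed alongside pentan-3-yl to do so. From the compounds shown here alone, it also remains open whether this position accepts anything other than plain carbon groups, such as a chain ending in an amine or a carboxylic acid, and how the mirror-image form of 1,2,2-trimethylpropyl compares.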